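Acylurea-hydrazone series: benzoyl aryl swap toward compound 4

This account rests on a few compounds, and the source may have more. Where it says the series, first, only, none or still open, it means among the compounds named here.

Measured so far in a functional assay on BCG823 cells (Homo sapiens) for inhibition, read by MTT assay, with a stated time of 72 h; on this read-out lower numbers stand for stronger inhibition and higher numbers for weaker inhibition:
compound 1 `CN(C(=O)NC(=O)c1ccccc1F)c1nc(C(F)(F)F)c(C(=O)N/N=C/c2ccc(C(F)(F)F)cc2)s1` gives 3.87 ug/mL
compound 2 `CN(C(=O)NC(=O)c1cccc([N+](=O)[O-])c1)c1nc(C(F)(F)F)c(C(=O)N/N=C/c2ccccc2C(F)(F)F)s1` gives 3.97 ug/mL
compound 3 `CN(C(=O)NC(=O)c1ccc(F)c(F)c1)c1nc(C(F)(F)F)c(C(=O)N/N=C/c2ccc(C(F)(F)F)cc2)s1` gives 3.85 ug/mL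

The three compounds share one core and differ only in the aryl on the acylurea carbonyl and in the placement of the trifluoromethyl on the hydrazone aryl. Compound 2 has the highest of the three numbers, yet its separation from compound 1 and from compound 3 is within the scatter, so the set reads as flat.

Compound 4 `CN(C(=O)NC(=O)c1ccc(C(F)(F)F)cc1)c1nc(C(F)(F)F)c(C(=O)N/N=C/c2ccccc2C(F)(F)F)s1` has not been measured. It differs from compound 2 as follows: 4-(trifluoromethyl)phenyl in place of 3-nitrophenyl on a carbonyl carbon

Among the measured compounds shown here, the one measured step that bears on this change is the step from compound 1 to compound 3, which also alters the aryl on the carbonyl carbon: a 1.0-fold lower number from compound 1 to compound 3 (0.00 log units; within the scatter). For the measured compounds named here, that step was flat, and no measured pair speaks to the swap of nitro for trifluoromethyl. Compound 4 is therefore expected to sit with the others, with a step of a 1.0-fold lower number from compound 2 to compound 4 (0.01 log units; within the scatter) in this assay not beyond the scatter. Compound 4 is estimated at 3.9 ug/mL, range 2 ug/mL to 7.8 ug/mL.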

Compound 4, half-maximal inhibitory concentration: 2.53 ug/mL
For compound 4 the middle estimate is 1.5-fold (0.19 log units) above the measured one; the range from low to high includes it.
By their numbers in this assay, from the lowest: compounds 4, 3, 1 and 2 (each within the scatter of the next).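

In this assay the swap on the carbonyl carbon gives a 1.6-fold lower number from compound 2 to compound 4 (0.20 log units; within the scatter) and so does not separate the two compounds. The earlier step at this position exchanged one fluorinated phenyl for another, whereas this one replaces 3-nitrophenyl, with its 2 hydrogen-bond acceptors, by 4-(trifluoromethyl)phenyl, with 0, and the reading still stays within the scatter. No measured property is available that would account for this reading.

On these data alone, all four compounds carry a substituted phenyl on the carbonyl carbon, so it remains open whether this position would stay as flat with a plain alkyl chain or with a phenyl bearing an amine or a carboxylic acid. The compounds shown also hold no pair that isolates the placement of the trifluoromethyl on the hydrazone aryl.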